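This account rests on a few compounds, and the source may have more. Where it says the series, first, only, none or still open, it means among the compounds named here.

Measured in a functional assay on DU-145 cells (Homo sapiens) for antiproliferative activity, read by WST assay, with a stated time of 3 days; a lower number here means a stronger inhibitor, a higher number a weaker inhibitor:

Compound 1 `CCOc1c(-c2cc(OC)c(OC)c(OC)c2)oc2ccccc2c1=O`: 6200 nM
Compound 2 `COc1cc(-c2oc3ccccc3c(=O)c2OC(C)C)cc(OC)c1OC`: > 50000 nM, a limit of the assay and not a number

Compound 2 therefore has no exact position in this assay, only (the limit of > 50000 nM in this assay, at which 1 of the 2 values shown sits). Compound 3 `CCC(C)Oc1c(-c2cc(OC)c(OC)c(OC)c2)oc2ccccc2c1=O` differs from it by methyl in place of hydrogen on a saturated chain carbon, two bonds along the chain from an oxygen on an aromatic ring: isopropoxy becomes sec-butoxy, with methyl in place of hydrogen on a saturated chain carbon, two bonds along the chain from an oxygen on an aromatic ring.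

The nearest measured change is an at least 8.0-fold higher number from compound 1 to compound 2 (0.90 log units; beyond the scatter). It also added a methyl to this chain, but on the carbon bound to the oxygen, and it weakened activity beyond the scatter. Going by these compounds, its full size is unknown, so it serves only as a guide to direction. Compound 3 is expected to stay weak, probably near the same limit, with no recovery towards compound 1. The expected step is a number no higher from compound 2 to compound 3 (the limit leaves the size open). Compound 3 is estimated at 50000 nM, within an expected range of 12000 nM to 100000 nM.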

Compound 3, half-maximal inhibitory concentration: > 50000 nM
Compound 3 gave a limit, no number; the forecaster's own chance of this, stated with the estimate: 65%; the middle value lies on the limit itself.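

In this assay, compound 3, which carries sec-butoxy, gives > 50000 nM, a limit of the assay and not a number. Compound 3 thus shows that adding a methyl two bonds along the chain from the oxygen does not bring a branched chain back into the measurable range, and the comparison with the shorter chain gives an at least 8.0-fold higher number from compound 1 to compound 3 (0.90 log units; beyond the scatter). The step between the two branched compounds cannot be read, so they can be placed together only at the same boundary: the limit of > 50000 nM in this assay, at which 2 of the 3 values shown sit.

Going by these compounds, whether sec-butoxy is any weaker or stronger than isopropoxy remains unknown, with compound 1 the only one of the three that has an exact number. Also open, on these data alone, is how an unbranched propoxy chain or a smaller methoxy group would fare in this assay.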